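A heteroaryl exchange from compound 3 to compound 4

The source may report more compounds than this note shows. Statements on the series, on what has been measured and on what is new or still open speak of the compounds shown alone.

Measured in a functional assay on A-375 cells (Homo sapiens) for activation, with a stated time of 3 days (on this read-out higher numbers stand for an effect only at larger amounts of compound and lower numbers for an effect already at smaller amounts), so far:
Compound 1 `O=C(Nc1ccc(-c2ccncc2)cc1)C1CCCN(Cc2ccc(F)c(F)c2)C1` gives 1180 nM
Compound 2 `O=C(Nc1ccc(-c2nccs2)cc1)C1CCCN(Cc2ccc(F)c(F)c2)C1` gives 800 nM
Compound 3 `O=C(Nc1ccc(-c2ccn[nH]2)cc1)C1CCCN(Cc2ccc(F)c(F)c2)C1` gives 580 nM

Compound 3 cannot be told apart from compound 2, as a 1.4-fold lower number from compound 2 to compound 3 (0.14 log units; within the scatter) shows. It stands lower than compound 1 by a modest margin, as a 2.0-fold lower number from compound 1 to compound 3 (0.31 log units; beyond the scatter) shows. Compound 4 `O=C(Nc1ccc(-c2cc[nH]c2)cc1)C1CCCN(Cc2ccc(F)c(F)c2)C1` has 1H-pyrrol-3-yl in place of 1H-pyrazol-5-yl on an aromatic carbon. The measured exchanges at this same place bear on the change, and besides those two, a 1.5-fold lower number from compound 1 to compound 2 (0.17 log units; within the scatter) also stays small. Within the data shown here, no measured compound yet carries this group. The step expected is a 1.1-fold higher number from compound 3 to compound 4 (0.05 log units; within the scatter) in this assay and it is estimated to stay within the scatter. The estimate for compound 4 is 650 nM (expected range 300 nM to 1400 nM).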

Compound 4, half-maximal effective concentration: 2610 nM
For compound 4 the middle estimate is 4.0-fold (0.60 log units) below the measured one; the whole stated range lies below it.
By their numbers in this assay, from the lowest: compounds 3, 2 and 1 (each within the scatter of the next, the first and the last beyond it); then compound 4.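

In this assay this position proves sensitive to the choice of five-membered ring: 1H-pyrrol-3-yl, which keeps the hydrogen-bond donor of 1H-pyrazol-5-yl but lacks its hydrogen-bond acceptor, raises the number (a 4.5-fold higher number from compound 3 to compound 4 (0.65 log units; beyond the scatter)). Compound 4 also stands clear of the other two compounds (a 3.3-fold higher number from compound 2 to compound 4 (0.51 log units; beyond the scatter); a 2.2-fold higher number from compound 1 to compound 4 (0.34 log units; beyond the scatter)), so the earlier small steps do not extend to every heteroaryl group here. No available evidence accounts for this loss. The compounds shown leave open whether the missing ring nitrogen or the point of attachment matters, and how 1H-pyrrol-2-yl would behave at this place.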